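Methoxy Added to the Benzyl Group of Compound 3

The compounds below may be only part of what the source reports. "The series", "measured", "known", "first", "only" and "open" are said of these compounds alone.

Compound 1 `COc1ccc(CNc2nc([SeH])nc3ccccc23)cc1`: > 100000 nM
Compound 2 `CSc1nc(NCc2ccc([Se]C)cc2)c2ccccc2n1`: > 100000 nM
Compound 3 `CSc1nc(NCc2ccccc2)c2ccccc2n1`: > 100000 nM

In a functional assay on CCRF-CEM cells (Homo sapiens) for cytotoxicity, read by MTT assay, with a stated time of 72 h (on this read-out higher numbers stand for lower toxicity in this test and lower numbers for higher toxicity in this test), compound 1 gives > 100000 nM, which is a limit of the assay and not a number. Compound 2 gives in this assay > 100000 nM, likewise a limit. Compound 3 gives in this assay > 100000 nM, again a limit, so compound 3 stands where every measured value stands (the limit of > 100000 nM in this assay, at which 3 of the 3 values shown sit). Among the compounds with values here, the only step between measured compounds, a step that the two limits leave unreadable from compound 2 to compound 3, is therefore of unknown size.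

Compound 4 `COc1ccc(CNc2nc(SC)nc3ccccc23)cc1` differs from compound 3 by methoxy in place of hydrogen on an aromatic carbon. Within the data shown here, no measured step speaks to this change; the single step available, a step that the two limits leave unreadable from compound 2 to compound 3, cannot be read. Compound 1 also carries a methoxy group on its benzyl ring and gives only a limit in this assay, which offers no sign that the methoxy brings toxicity into view. The step expected in this assay is a number no higher from compound 3 to compound 4 (the limit leaves the size open), most likely nothing beyond the scatter. Compound 4 is therefore expected to give about 100000 nM, within 40000 nM to 300000 nM, and most probably again only a limit.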

Compound 4, concentration lethal to 50% of the cells: > 100000 nM
Compound 4: no number, only a limit; the forecaster's own chance of this, stated with the estimate: 85%; the middle value lies on the limit itself.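

Compound 4 gives only a limit in this assay, as do compound 1, compound 2 and compound 3, so none of the new steps to compound 4 can be read: the limit of > 100000 nM in this assay, at which 4 of the 4 values shown sit.

The compounds shown leave open whether methoxy in place of hydrogen, or any other change among them, alters toxicity in this assay.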